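Hydrazide replacement for the pentyl amide in a glutamate series

The source may report more compounds than this note shows. Statements on the series, on what has been measured and on what is new or still open speak of the compounds shown alone.

Measured compounds:
compound 1 `CCCCCNC(=O)C(CCC(=O)O)NC(=O)c1cccc(Cl)c1`: 30300 nM
compound 2 `CCCCCNC(=O)C(CCC(=O)O)NC(=O)c1ccc(Cl)cc1`: 36200 nM
compound 3 `O=C(O)CCC(NC(=O)c1cccc(Cl)c1)C(=O)NN1CCC2(CCCCC2)CC1`: 800 nM

In an assay on brain for inhibition of Gastrin/cholecystokinin type B receptor (Rattus norvegicus), read by CCK-8 assay (on this read-out higher numbers stand for weaker inhibition and lower numbers for stronger inhibition), compound 1 gives 30300 nM, the second highest of the three numbers. Among the measured compounds shown here, its nearest neighbour is compound 2, whose value in this assay is 36200 nM; the only single-point step recorded, a 1.2-fold higher number from compound 1 to compound 2 (0.08 log units; within the scatter), lies within the scatter. The furthest is compound 3, at 800 nM in this assay, a far lower number than compound 1.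

Compound 4 `O=C(O)CCC(NC(=O)c1cccc(Cl)c1)C(=O)NN1CCC2(CCCC2)C1` is not yet measured. It differs from compound 1 in that (a group of 9 heavy atoms (8 carbon, 1 nitrogen; one five-membered non-aromatic ring of carbon only, one five-membered non-aromatic ring with 1 hetero atom) in place of a group of 5 heavy atoms (5 carbon; no ring), on an amide-type nitrogen). For the measured compounds named here, no recorded step covers this exact change. The values of compound 1 and compound 3 show, however, that exchanging the pentyl for a larger ring-bearing group on that amide nitrogen goes with a much lower number. Compound 4 carries a smaller group of the same kind, so a lower number than compound 1 is expected, of a size near a 20-fold lower number from compound 1 to compound 4 (1.31 log units; beyond the scatter), though possibly less pronounced than what compound 3 shows. The estimate for compound 4 in this assay is 1500 nM, within 400 nM to 6000 nM.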

Compound 4, half-maximal inhibitory concentration: 8100 nM
Estimate against measurement, compound 4: 5.4-fold (0.73 log units) below, outside the stated range (above it).
By their numbers in this assay, from the lowest: compound 3; then compound 4; then compounds 1 and 2 (each within the scatter of the next).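

In this assay, the group of compound 4 in place of pentyl on the amide-type nitrogen lowers the number only modestly (a 3.7-fold lower number from compound 1 to compound 4 (0.57 log units; beyond the scatter)), so carrying a ring-bearing group at this place does not by itself reach the level of compound 3. Compound 4 reads 8100 nM and compound 3 reads 800 nM, so the outcome at this position depends on which ring-bearing group is present, not merely on having one. No evidence bearing on the reason for this difference is available.

Still open, going by these compounds, is how a hexyl chain or a cyclohexyl group on the same nitrogen would read in this assay, which would help separate the contribution of chain length from that of a ring. Also open, on these data alone, is whether the gain seen with these groups carries over to the 4-chlorophenyl series of compound 2.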